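The compounds below may be only part of what the source reports. "The series", "measured", "known", "first", "only" and "open" are said of these compounds alone.

Measured so far:

Compound 1, `COc1ccc(N2CCN(C(=S)SCc3ccc(C(=O)Nc4ccccc4N)cc3)CC2)cc1`: 28.1%
Compound 2, `CN(Cc1ccncc1)C(=S)SCc1ccc(C(=O)Nc2ccccc2N)cc1`: 31.4%

Of the compounds shown here, two have been read in a functional assay on A-375 cells (Homo sapiens) for antiproliferative activity, read by CCK-8 assay, with a stated time of 72 h, tested at 2 uM; a higher number here means a stronger effect of the compound at the concentration tested, a lower number a weaker effect. Compound 1, with structure `COc1ccc(N2CCN(C(=S)SCc3ccc(C(=O)Nc4ccccc4N)cc3)CC2)cc1`, gives 28.1% in this assay, and compound 2, with structure `CN(Cc1ccncc1)C(=S)SCc1ccc(C(=O)Nc2ccccc2N)cc1`, gives 31.4%. Going by the values given here, the two numbers lie within the usual scatter of each other, so compound 1 cannot be placed above or below compound 2 on these data; the two readings say only that both compounds show a modest effect at the concentration tested.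

The next compound, compound 3, has structure `Nc1ccccc1NC(=O)c1ccc(CSC(=S)N2CCN(C3CCCCC3)CC2)cc1` and is still to be measured in this assay. It differs from compound 1 in one place: cyclohexyl in place of 4-methoxyphenyl on an amine nitrogen in a ring. No pair of measured compounds tracks a change of this kind, so there is no shown step to lean on. The expectation is therefore a step of no more than the scatter in either direction, a number 1.9 percentage points higher from compound 1 to compound 3 (within the scatter), with the reading of compound 3 staying near that of compound 1. Compound 3 is estimated at 30%, with a range from 15% to 48%.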

Compound 3, a percentage reported as inhibition, at one concentration (the size of the read-out at that concentration, not a potency): 31.7%
For compound 3 the middle estimate is 1.7 percentage points below the measured one; the range from low to high includes it.
By their numbers in this assay, from the lowest: compounds 1, 2 and 3 (each within the scatter of the next).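

In this assay, going by these compounds alone, cyclohexyl in place of 4-methoxyphenyl on the amine nitrogen in the ring gives a number 3.6 percentage points higher from compound 1 to compound 3 (within the scatter), the first step that can be read at this position. At this position, then, a six-membered aromatic ring of carbon only, with its 8 heavy atoms and 1 hydrogen-bond acceptor, and a six-membered non-aromatic ring of carbon only, with its 6 heavy atoms and no hydrogen-bond acceptor, do not separate compound 1 from compound 3 in this read-out. No measurement shown here bears on this result, and the step itself offers no explanation of it.

Whether a methyl group, a longer alkyl chain, a basic amine or a carboxylic acid on this ring nitrogen would give a step beyond the scatter remains open among the compounds shown. Within the data shown here, the single step covers only two groups that each carry a six-membered ring, and a reading at one concentration gives no potency for compound 1 or compound 3.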